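A few compounds are considered here, and "the series" means these few. Any claim that something is new, unique, unknown or untested is made for them only; others in the source may bear on it.

In a functional assay on HeLa cells (Homo sapiens) for cytotoxicity, read by MTT assay (on this read-out higher numbers stand for weaker inhibition and lower numbers for stronger inhibition), compound 3 `COc1ccc2[nH]c(-c3ccccc3)c(C(c3c[nH]c4ccccc34)C3C(=O)NN=C3C)c2c1` gives 1700 nM and stands at the low end of the three numbers shown, within the scatter of compound 1 yet beyond it from compound 2. Compound 1 `CC1=NNC(=O)C1C(c1c[nH]c2ccccc12)c1c(-c2ccccc2)[nH]c2ccc(C)cc12` gives 2400 nM and compound 2 `CC1=NNC(=O)C1C(c1c[nH]c2ccccc12)c1c(-c2ccccc2)[nH]c2ccc(Cl)cc12` gives 3800 nM. The step of a 1.4-fold lower number from compound 1 to compound 3 (0.15 log units; within the scatter) lies within the scatter, whereas a 2.2-fold lower number from compound 2 to compound 3 (0.35 log units; beyond the scatter) is a modest change. Compound 4 `CC1=NNC(=O)C1C(c1c[nH]c2ccccc12)c1c(-c2ccccc2)[nH]c2ccccc12` differs from compound 3 by hydrogen in place of methoxy on an aromatic carbon. Among the measured compounds shown here, no measured step removes a group from this place entirely; the two steps that reach it show only that methoxy gives a somewhat lower number than methyl or chloro. Removing it is therefore expected to raise the number slightly, probably within the scatter, so compound 4 is estimated at 2500 nM, with a range from 1200 nM to 5000 nM. This estimate means a step of a 1.5-fold higher number from compound 3 to compound 4 (0.17 log units; within the scatter).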

Compound 4, half-maximal inhibitory concentration: 7700 nM
The estimate for compound 4 lay 3.1-fold (0.49 log units) below the measured number; measured number above the stated range.
By their numbers in this assay, from the lowest: compounds 3, 1 and 2 (each within the scatter of the next, the first and the last beyond it); then compound 4.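

Carrying a group at this place matters more than which of the three groups it is: there is a 4.5-fold higher number from compound 3 to compound 4 (0.66 log units; beyond the scatter) and a 3.2-fold higher number from compound 1 to compound 4 (0.51 log units; beyond the scatter) as well as a 2.0-fold higher number from compound 2 to compound 4 (0.31 log units; beyond the scatter) in this assay and compound 4, with hydrogen, gives the highest number of the four. The earlier compounds shown here compared only methyl, chloro and methoxy with one another, so they could not show this. Nothing shown here explains why hydrogen stands apart.

On these data alone, whether an amine, a carboxylic acid or a longer chain such as ethoxy at this place would also give a lower number than hydrogen remains open.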